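Inverting one saturated chain stereocentre: working notes

The source may report more compounds than this note shows. Statements on the series, on what has been measured and on what is new or still open speak of the compounds shown alone.

In an ADME assay on L1210 cells (Mus musculus) for cytotoxicity, with a stated time of 48 h (a lower number here means a stronger inhibitor, a higher number a weaker inhibitor), compound 1 `COC1=CC(=O)C(O)=C(C/C=C(\C)CC[C@@]2(C)CCC=C(C)[C@H]2C)C1=O` gives 2 ug/mL. Compound 2 `CC1=CCC[C@](C)(CC/C(C)=C/CC2=C(O)C(=O)C=C(N[C@H](C(=O)O)[C@H](C)O)C2=O)[C@@H]1C` gives > 10 ug/mL, which is a limit of the assay and not a number. Placing (1-carboxy-2-hydroxypropyl)amino in place of methoxy on a double-bonded ring carbon is the only measured step, an at least 5.0-fold higher number from compound 1 to compound 2 (0.69 log units; beyond the scatter), beyond the scatter. Compound 3 `CC1=CCC[C@](C)(CC/C(C)=C/CC2=C(O)C(=O)C=C(N[C@@H](C(=O)O)[C@H](C)O)C2=O)[C@@H]1C` follows from compound 2 by one change: the two compounds have the same atoms and bonds and differ only in configuration as drawn: 1 of 5 stereo elements differ; a stereocentre at a saturated chain carbon is drawn S in compound 2 and R in compound 3. That measured step does not test configuration, so no shift beyond the scatter is expected in this assay. The expected step is a step that the limit leaves unreadable from compound 2 to compound 3. For compound 3 the estimate is 12 ug/mL, with an expected range of 5 ug/mL to 30 ug/mL.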

Compound 3, half-maximal inhibitory concentration: > 10 ug/mL
Compound 3 gave a limit, no number; the forecaster's own chance of this, stated with the estimate: 65%; the middle value does not contradict the limit.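

In this assay, the (1-carboxy-2-hydroxypropyl)amino group in place of methoxy holds its loss with the saturated chain carbon drawn R as well as S: an at least 5.0-fold higher number from compound 1 to compound 3 (0.69 log units; beyond the scatter). The step between compound 2 and compound 3 cannot be read, because both values are limits and not numbers: the limit of > 10 ug/mL in this assay, at which 2 of the 3 values shown sit.

Going by these compounds, whether the configuration at this carbon matters therefore stays open, even though it is the only difference: the fact that compounds 2 and 3 differ only in the configuration as drawn Also open is whether a plain amine in place of methoxy, without the carboxylic acid, would give a readable number.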